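This account rests on a few compounds, and the source may have more. Where it says the series, first, only, none or still open, it means among the compounds named here.

Compound 1 `CCN(C/C=C/C#CC(C)(C)C)Cc1cccc(OC[Si](C)(C)c2ccc(F)cc2)c1` gives 60 nM in a functional assay on liver (Sus scrofa) for inhibition of squalene monooxygenase (Homo sapiens), using microsomes; a higher number here means a weaker inhibitor, a lower number a stronger inhibitor.
Compound 2 `CCN(C/C=C/C#CC(C)(C)C)Cc1cccc(OC[Si](C)(C)c2ccc(Br)cc2)c1` gives 210 nM in this assay.

Compound 2 thus stands at the highest of the two numbers measured; its nearest neighbour is compound 1, whose value is separated from it by the step of a 3.5-fold higher number from compound 1 to compound 2 (0.54 log units; beyond the scatter), a change at a single aromatic carbon. Compound 3 `CCN(C/C=C/C#CC(C)(C)C)Cc1cccc(OC[Si](C)(C)c2ccc(C)cc2)c1` differs from compound 2 at that same carbon: methyl in place of bromo on an aromatic carbon. Among the measured compounds shown here, the one measured step is the only guide, since nothing with a methyl at this carbon has yet been measured. That step was modest yet beyond the scatter, so a second exchange at the same position is expected to move the number by a comparable or smaller amount, with the direction uncertain. Compound 3 is therefore estimated to give 130 nM in this assay, within 45 nM to 380 nM. The expected step is a 1.6-fold lower number from compound 2 to compound 3 (0.21 log units; within the scatter).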

Compound 3, half-maximal inhibitory concentration: 120 nM
Compound 3: middle estimate off by 1.1-fold (0.03 log units), on the high side; low and high end bracket the measured number.
By their numbers in this assay, from the lowest: compounds 1, 3 and 2 (each within the scatter of the next, the first and the last beyond it).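

In this assay, methyl at this aromatic carbon gives a 1.8-fold lower number from compound 2 to compound 3 (0.24 log units; within the scatter) and a 2.0-fold higher number from compound 1 to compound 3 (0.30 log units; within the scatter) and so stands within the scatter of both halogen compounds. Compound 3 therefore cannot be told apart from either compound 1 or compound 2, even though those two lie beyond the scatter of each other. Among fluoro, methyl and bromo, then, the only difference this position shows beyond the scatter is the one between the two halogens, and it is modest.

On these data alone, whether the position would stay this forgiving with a methoxy, a trifluoromethyl, a carboxylic acid, an amine or a plain hydrogen on this carbon remains open, as does the effect of a longer chain there. Nothing at hand bears on what lies behind these numbers.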